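Chlorophenyl amide variants: working notes on the series

The source may report more compounds than this note shows. Statements on the series, on what has been measured and on what is new or still open speak of the compounds shown alone.

Measured so far in a functional assay on HCT-116 cells (Homo sapiens) for inhibition, read by MTT assay, with a stated time of 72 h; a higher number here means a weaker inhibitor, a lower number a stronger inhibitor:
compound 1 `O=C(Nc1ccccc1Cl)c1ccc(/N=N\c2c[nH]c3ccccc23)cc1` gives 120000 nM
compound 2 `O=C(Nc1cccc(Cl)c1)c1ccc(/N=N\c2c[nH]c3ccccc23)cc1` gives 80000 nM

Compound 1 holds the highest of the two numbers, though its nearest neighbour compound 2 sits within the scatter of it. For the measured compounds named here, the only measured step, a 1.5-fold lower number from compound 1 to compound 2 (0.18 log units; within the scatter), moves the chlorine on the amide-type nitrogen's phenyl ring and changes nothing beyond the scatter.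

The next compound, compound 3 `O=C(Nc1ccc(Cl)cc1)c1ccc(/N=N\c2c[nH]c3ccccc23)cc1`, differs from compound 1 by 4-chlorophenyl in place of 2-chlorophenyl on an amide-type nitrogen. Going by the values given here, only the step from compound 1 to compound 2 bears on this move, and it was flat, so a comparably small step in this assay is expected, if anything toward a slightly lower number. The expected step from compound 1 to compound 3 is a 1.5-fold lower number from compound 1 to compound 3 (0.18 log units; within the scatter). For compound 3 the estimate in this assay is 80000 nM, with a range from 30000 nM to 200000 nM.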

Compound 3, half-maximal inhibitory concentration: 187000 nM
Estimate against measurement, compound 3: 2.3-fold (0.37 log units) below; the measured number falls inside the stated range.
By their numbers in this assay, from the lowest: compounds 2, 1 and 3 (each within the scatter of the next, the first and the last beyond it).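

In this assay, 4-chlorophenyl in place of 2-chlorophenyl on the amide-type nitrogen gives a 1.6-fold higher number from compound 1 to compound 3 (0.19 log units; within the scatter) and so leaves these two compounds indistinguishable. For the compounds shown here, the same group in place of 3-chlorophenyl gives a 2.3-fold higher number from compound 2 to compound 3 (0.37 log units; beyond the scatter) and is the first step to pass the scatter, showing a modest sensitivity at this position to where the chlorine stands, although compound 1 cannot be separated from either of the other two. Nothing available bears on what lies behind this small difference.

From the compounds shown here alone, all three compounds carry one chlorine on this phenyl ring, so the effect of a methoxy group, an amine or a carboxylic acid there remains open. Also open, going by these compounds, is whether changes to the shared core would bring a larger step than any seen here.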